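A Piperazine Aryl Swap Tested Against Electroshock

The source may report more compounds than this note shows. Statements on the series, on what has been measured and on what is new or still open speak of the compounds shown alone.

Compound 2 `CC(C(=O)N1CCN(c2cccc(Cl)c2)CC1)N1C(=O)CCC1=O` was measured in a functional assay on the whole organism (strain Swiss) with Mus musculus as the target, in the maximal electroshock model, with a stated time of 0.25 h, at a dose of 300 mg/kg by the intraperitoneal route (on this read-out higher numbers stand for a stronger effect at the one dose given and lower numbers for a weaker effect), where compound 2 gives 75%. Compound 1 `CCC(C(=O)N1CCN(c2cccc(Cl)c2)CC1)N1C(=O)CCC1=O` gives 75% in this assay, and the step of no change at the digits printed from compound 1 to compound 2 (within the scatter) shows the two standing level. Compound 3 `CCC(C(=O)N1CCN(c2ccc(Cl)cc2)CC1)N1C(=O)CCC1=O`, by contrast, gives 0% in this assay, so compound 2 and compound 1 together stand well above compound 3.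

Compound 4 `CC(C(=O)N1CCN(c2ccccc2F)CC1)N1C(=O)CCC1=O` has not been measured. It differs from compound 2 in one place: 2-fluorophenyl in place of 3-chlorophenyl on an amine nitrogen in a ring.

Going by the values given here, one measured step bears on this change. From compound 1 to compound 3 the chlorine on the phenyl ring changed position, and this assay fell by a number 75 percentage points lower from compound 1 to compound 3 (beyond the scatter). Among the compounds with values here, that single step shows that the aryl group on the piperazine nitrogen can decide the read-out, though no measured compound carries a 2-fluorophenyl, so the direction for compound 4 rests on thin ground. Because a number 75 percentage points lower from compound 1 to compound 3 (beyond the scatter) was a large loss, a fall is expected for compound 4, with the estimated step being a number 40 percentage points lower from compound 2 to compound 4 (beyond the scatter). Compound 4 is therefore estimated at 35% in this assay, within a range from 0% to 75%.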

Compound 4, a percentage reported as activity, at one dose (the size of the read-out at that dose, not a potency): 100%
Compound 4: middle estimate off by 65 percentage points, on the low side; the whole stated range lies below it.
By their numbers in this assay, from the lowest: compound 3; then compounds 1 and 2 (each within the scatter of the next); then compound 4.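

Replacing 3-chlorophenyl with 2-fluorophenyl gave a number 25 percentage points higher from compound 2 to compound 4 (beyond the scatter) in this assay, so the aryl group on this amine nitrogen in a ring can raise the read-out as well as remove it. Going by these compounds alone, the only earlier aryl change, on the core of compound 1, went the other way, with a number 75 percentage points lower from compound 1 to compound 3 (beyond the scatter); the two changes together show that the read-out responds strongly to the aryl group in both directions. Nothing available here accounts for the gain seen with compound 4.

This step changes the halogen and its place on the phenyl ring together, and the compounds shown do not separate the two. On these data alone, whether 2-fluorophenyl would hold this level on the core of compound 1, and how an unsubstituted phenyl or a methoxyphenyl would read at this place, remains open.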